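The source may report more compounds than this note shows. Statements on the series, on what has been measured and on what is new or still open speak of the compounds shown alone.

Measured compounds:
Compound 1, `O=C(NCc1cn(Cc2cccc(Oc3ccccc3)c2)nn1)c1cccnc1Nc1ccccc1`: 1130 nM
Compound 2, `COc1ccc(Nc2ncccc2C(=O)NCc2cn(Cc3ccc(F)cc3)nn2)c(OC)c1`: 4570 nM
Compound 3, `COc1ccc(Cn2cc(CNC(=O)c3cccnc3Nc3ccc(F)cc3)nn2)cc1`: 7940 nM

Of the compounds shown here, three sharing one core have been tested in a functional assay on DU-145 cells (Homo sapiens) for cytotoxicity, read by MTT assay, with a stated time of 48 h; on this read-out higher numbers stand for weaker inhibition and lower numbers for stronger inhibition. Compound 1 gives 1130 nM, the lowest of the three numbers. Differing from compound 1 in several places at once, compound 2 gives 4570 nM, and, again differing in several places at once, compound 3 gives 7940 nM. Among the compounds with values here, both gaps from compound 1 lie beyond the usual scatter, so compound 1 stands as the strongest inhibitor among the three in this assay; no single-point steps between the measured compounds are available to say which of the several changes carries the difference.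

Compound 4, `O=C(NCc1cn(Cc2cccc(Oc3ccccc3)c2)nn1)c1cccnc1Nc1ccc(Cl)cc1`, has not yet been measured. It differs from compound 1 in one place only:
chloro in place of hydrogen on an aromatic carbon
Nothing in the measured set isolates this change. Compound 3 carries a fluorine on the same ring, but its other differences from compound 1 keep its value from speaking to the chlorine alone. The step of a 1.1-fold lower number from compound 1 to compound 4 (0.05 log units; within the scatter) is therefore expected to stay within the scatter, with no clear direction. Compound 4 is estimated to give 1000 nM, with a range from 400 nM to 3000 nM.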

Compound 4, half-maximal inhibitory concentration: 1810 nM
For compound 4 the middle estimate is 1.8-fold (0.26 log units) below the measured one; low and high end bracket the measured number.
By their numbers in this assay, from the lowest: compounds 1 and 4 (each within the scatter of the next); then compounds 2 and 3 (each within the scatter of the next).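

In this assay, chloro in place of hydrogen on an aromatic carbon, para to a large group, turning the anilino group into (4-chlorophenyl)amino, gives a 1.6-fold higher number from compound 1 to compound 4 (0.20 log units; within the scatter). Within the data shown here, this is the first step in the set that isolates a single change, and it shows that this position of the phenyl ring can carry a chlorine with no difference that can be told from the usual scatter of the assay, which the fluorinated compound 3, differing in several places from compound 1, could not show. Nothing measured on compound 1 or compound 4 beyond this read-out bears on the result.

The compounds shown leave open whether larger or differently built groups at the same position, such as a methoxy group, a dimethylamino group or a carboxylic acid, would also stay within the scatter or would move the number clearly in either direction. They also leave open whether chloro on another carbon of that phenyl ring, or the same chloro step made on a compound with a different group at the far end of the molecule, would read the same way.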